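The compounds below may be only part of what the source reports. "The series", "measured", "known", "first", "only" and "open" are said of these compounds alone.

Measured compounds:
- compound 1, `COc1ccc(/C=N/NC(=O)c2ccc(-c3nc4ccccc4s3)cc2)c(O)c1`: in an assay on isolated protein for inhibition of Maltase-glucoamylase (Homo sapiens), with a stated time of 15 min (on this read-out lower numbers stand for stronger inhibition and higher numbers for weaker inhibition), compound 1 gives 6970 nM
- compound 2, `O=C(N/N=C/c1cccc(O)c1)c1ccc(-c2nc3ccccc3s2)cc1`: in this assay compound 2 gives 9210 nM

Compound 2 stands alongside compound 1 on the two numbers available; the step of a 1.3-fold higher number from compound 1 to compound 2 (0.12 log units; within the scatter) lies within the scatter, so the two hydroxyphenyl-bearing compounds cannot be separated on this read-out.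

Compound 3, `COc1cc(/C=N/NC(=O)c2ccc(-c3nc4ccccc4s3)cc2)ccc1O`, differs from compound 2 only by 4-hydroxy-3-methoxyphenyl in place of 3-hydroxyphenyl on a carbon with a double bond to nitrogen. For the measured compounds named here, the one measured step that bears on this change is a 1.3-fold higher number from compound 1 to compound 2 (0.12 log units; within the scatter): it concerns the same aryl group at the same place, swaps one hydroxy-methoxy substitution pattern for a plain hydroxy group, and stays within the scatter. Going by the values given here, no step for the 4-hydroxy-3-methoxy pattern itself is available, so its effect is taken as unknown beyond that precedent.

On this basis no step beyond the scatter is expected in this assay; the expected step is a 1.2-fold lower number from compound 2 to compound 3 (0.06 log units; within the scatter). Compound 3 is therefore estimated at 8000 nM, with a range from 3500 nM to 18000 nM.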

Compound 3, half-maximal inhibitory concentration: 53300 nM
Compound 3: the middle estimate sits 6.7-fold (0.82 log units) below what was measured, and the stated range ends below it.
By their numbers in this assay, from the lowest: compounds 1 and 2 (each within the scatter of the next); then compound 3.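

In this assay, the aryl group on the carbon with a double bond to nitrogen now shows a change beyond the scatter: 4-hydroxy-3-methoxyphenyl in place of 3-hydroxyphenyl gives a 5.8-fold higher number from compound 2 to compound 3 (0.76 log units; beyond the scatter), and in place of 2-hydroxy-4-methoxyphenyl it gives a 7.6-fold higher number from compound 1 to compound 3 (0.88 log units; beyond the scatter). This position is therefore not indifferent to the aryl substitution, as the pair of compound 1 and compound 2 alone might have suggested. Compound 1 and compound 3 both carry one hydroxy and one methoxy group, so among these three compounds the higher number goes with the arrangement of the two groups rather than with the mere presence of a methoxy group, and nothing available accounts for the shift.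

Going by these compounds, the two groups of compound 3 cannot be judged separately here, so it remains open whether the step follows the placing of the hydroxy group, that of the methoxy group, or the two together. Also open, on these data alone, is how this position responds to an unsubstituted phenyl, to an aryl group carrying an amine or a carboxylic acid, or to a longer alkoxy chain in place of methoxy.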